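Pyridine for Phenyl on the Ring-Borne Sulfonyl

The source may hold more compounds than are shown below. What is called first, only, known or untested is meant among the compounds shown, and "the series" means these compounds.

Compound 2 `N#Cc1ccc(S(=O)(=O)N2C[C@H](S(=O)(=O)c3ccc(Cl)cc3)[C@](O)(CO)C2)c(Cl)c1` stands, together with compound 1 `N#Cc1ccc(S(=O)(=O)[C@H]2CN(S(=O)(=O)c3ccc(C#N)cc3Cl)C[C@@]2(O)CO)cc1`, at the lowest number among three compounds in an assay on cells for antagonist activity at transient receptor potential cation channel subfamily V member 4 (Homo sapiens), read by FLIPR and calcium flux, with a stated time of 10 min; on this read-out lower numbers stand for stronger inhibition and higher numbers for weaker inhibition: compound 2 gives 3.2 nM, and compound 1 gives 3.2 nM, the two within the scatter of each other (no change at the digits printed from compound 1 to compound 2 (within the scatter)). Compound 3 `N#Cc1ccc(S(=O)(=O)N2C[C@H](S(=O)(=O)c3ccc(Cl)cc3)[C@](O)(CO)C2)cn1` sits far apart, at 631 nM in this assay.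

Compound 4 `N#Cc1ccc(S(=O)(=O)N2C[C@H](S(=O)(=O)c3ccc(Cl)cn3)[C@](O)(CO)C2)c(Cl)c1` differs from compound 2 in one place: 5-chloropyridin-2-yl in place of 4-chlorophenyl on a sulfonyl sulfur. For the measured compounds named here, of the measured steps, the one from compound 2 to compound 3 bears most directly on it, since it also exchanges a carbon-only aromatic ring for a pyridine ring on a sulfonyl sulfur, though on the other sulfonyl of the shared core, and it was large: a 200-fold higher number from compound 2 to compound 3 (2.29 log units; beyond the scatter). The step from compound 1 to compound 2 touches neither sulfonyl ring in this way and offers no guidance.

Compound 4 is therefore expected to lie beyond the scatter in the weaker direction, with an estimated step of a 16-fold higher number from compound 2 to compound 4 (1.19 log units; beyond the scatter) in this assay. The estimate for compound 4 is 50 nM, with a range from 6 nM to 400 nM.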

Compound 4, half-maximal inhibitory concentration: 5 nM
Estimate against measurement, compound 4: 10-fold (1.00 log units) above, and the stated range ends above it.
By their numbers in this assay, from the lowest: compounds 1, 2 and 4 (each within the scatter of the next); then compound 3.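

On the sulfonyl sulfur whose other neighbour is a saturated ring carbon, 5-chloropyridin-2-yl serves in this assay about as well as 4-chlorophenyl, with a 1.6-fold higher number from compound 2 to compound 4 (0.19 log units; within the scatter), and as well as the 4-cyanophenyl of compound 1, with a 1.6-fold higher number from compound 1 to compound 4 (0.19 log units; within the scatter). A pyridine ring on a sulfonyl sulfur therefore does not by itself carry a large penalty in this series, even though the exchange of 2-chloro-4-cyanophenyl for 6-cyanopyridin-3-yl gave a 200-fold higher number from compound 2 to compound 3 (2.29 log units; beyond the scatter). Nothing given here explains why these two exchanges differ so widely.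

The compounds shown leave open whether a pyrimidine ring would serve as well as the pyridine ring of compound 4. They also leave open whether a methoxy group or an amine could stand in place of its chlorine.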